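This account rests on a few compounds, and the source may have more. Where it says the series, first, only, none or still open, it means among the compounds named here.

Measured so far in a functional assay on BMDM cells (Mus musculus, strain C57BL/6) for inhibition, with a stated time of 2 days; on this read-out higher numbers stand for weaker inhibition and lower numbers for stronger inhibition:
Compound 1 `COc1ccc(-c2cn(CC(=O)Nc3nc4ccccc4s3)nn2)cc1` gives 1330 nM.
Compound 2 `COc1cccc(-c2cn(-c3ccc(C(F)(F)F)cc3)nc2C(=O)N2CCN(c3ncccn3)CC2)c1` gives only a limit of the assay, > 30000 nM.
Compound 3 `Cc1csc(NC(=O)Cn2cc(-c3ccccc3Cl)nn2)n1` gives 1240 nM.

Of the two compounds that give a number, compound 1 has the highest value; its nearest neighbour is compound 3, and the gap between them lies within the usual scatter of this kind of measurement, so the two cannot be told apart. Compound 2 stands at the limit of > 30000 nM in this assay, at which 1 of the 3 values shown sits, which is a limit and not a number.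

Compound 4 `O=C(Cn1cc(-c2ccccc2Cl)nn1)Nc1nc2ccccc2s1` has not yet been tested in this assay. It differs from compound 1 in one place: 2-chlorophenyl in place of 4-methoxyphenyl on an aromatic carbon. Among the measured compounds shown here, no measured pair shows this change by itself. Compound 3, which also carries a 2-chlorophenyl group, gives 1240 nM, a value within the scatter of compound 1, so the change is expected to leave the number roughly where it is. The step of a 1.0-fold lower number from compound 1 to compound 4 (0.01 log units; within the scatter) is therefore expected to be small, with no clear direction. Compound 4 is estimated at 1300 nM, within a range from 400 nM to 4500 nM.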

Compound 4, half-maximal inhibitory concentration: > 30000 nM
Compound 4: only a limit was reported; the forecaster's own chance of this, stated with the estimate: 5%; middle value at least 23-fold (1.36 log units) from the limit.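

In this assay, among the compounds shown here, this position on the five-membered aromatic ring with 3 nitrogen proves sensitive, which the earlier compounds did not show: 2-chlorophenyl in place of 4-methoxyphenyl brings an at least 22-fold higher number from compound 1 to compound 4 (1.35 log units; beyond the scatter). Compound 3 carries the same 2-chlorophenyl group with a different remainder and gives 1240 nM, so the group alone does not decide the outcome, and its effect depends on the rest of the molecule. Compound 4 now stands with compound 2 at a limit of the assay, which is not a number: the limit of > 30000 nM in this assay, at which 2 of the 4 values shown sit.

The compounds shown cannot tell whether the loss follows from gaining the chlorine, from losing the methoxy group, or from where the substituent sits on the phenyl ring. A plain phenyl, a 4-chlorophenyl or a 2-methoxyphenyl on the same core would help to separate these possibilities.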